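The source may report more compounds than this note shows. Statements on the series, on what has been measured and on what is new or still open speak of the compounds shown alone.

Compound 1 `O=C(N/N=C/C1CCCCC1)c1ccc(O[C@@H]2O[C@H](CO)[C@@H](O)[C@H](O)[C@H]2O)cc1` gives 0.88%; compound 2 `CC(=O)OC[C@H]1O[C@@H](Oc2ccc(-c3nnc(C4CCCCC4)o3)cc2)[C@H](OC(C)=O)[C@@H](OC(C)=O)[C@@H]1OC(C)=O` gives 11.6%.

In a functional assay on MDA-MB-231 cells (Homo sapiens) for inhibition, read by MTT assay, with a stated time of 24 h, tested at 100 uM (a lower number here means less inhibition, a higher number more inhibition at the concentration tested (going by the name of the read-out)), compound 1 stands lowest of the two numbers shown, and compound 2 gives a number higher than that of compound 1 by more than the usual scatter. Compound 3 `O=C(N/N=C/c1ccccc1)c1ccc(O[C@@H]2O[C@H](CO)[C@@H](O)[C@H](O)[C@H]2O)cc1` has not yet been measured. It differs from compound 1 in one place: phenyl in place of cyclohexyl on a carbon with a double bond to nitrogen. Going by the values given here, no step between measured compounds that differ in one place is known, so the effect of this change rests on no measured pair. Since compound 1 gives 0.88%, only a small step is expected, a number 4.1 percentage points higher from compound 1 to compound 3 (within the scatter), not beyond the scatter. Compound 3 is thus expected to give about 5%, in the range -5% to 20%.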

Compound 3, a percentage reported as inhibition, at one concentration (the size of the read-out at that concentration, not a potency): 3.56%
Compound 3: the middle estimate sits 1.4 percentage points above what was measured; low and high end bracket the measured number.
By their numbers in this assay, from the lowest: compounds 1, 3 and 2 (each within the scatter of the next, the first and the last beyond it).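

In this assay, going by these compounds alone, the first measured pair at this position gives a number 2.7 percentage points higher from compound 1 to compound 3 (within the scatter) for phenyl in place of cyclohexyl on a carbon with a double bond to nitrogen. An aromatic and a non-aromatic six-membered ring of carbon therefore cannot be told apart here, at least on the core of compound 1. No available evidence bears on this result. On these data alone, what remains open is whether an amine, a carboxylic acid or a longer chain in place of these rings on this carbon would give a number beyond the scatter from compound 1.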